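The source may hold more compounds than are shown below. What is called first, only, known or untested is meant among the compounds shown, and "the series" means these compounds.

Of the compounds shown here, three built on one shared core have been tested in a functional assay on PC-3 cells (Homo sapiens) for inhibition, read by sulforhodamine B assay, with a stated time of 72 h; a higher number here means a weaker inhibitor, a lower number a stronger inhibitor. Compound 1 `Nc1sc(-c2ccc(Cl)cc2)c(-c2ccc(Cl)cc2)c1C(=O)NC1CCCCC1` gives 7300 nM in this assay. Compound 2 `COc1ccc(CNC(=O)c2c(N)sc(-c3ccc(Cl)cc3)c2-c2ccc(Cl)cc2)cc1` gives 29500 nM, and compound 3 `Nc1sc(-c2ccc(Cl)cc2)c(-c2ccc(Cl)cc2)c1C(=O)N1CCC(=O)CC1=O` gives 9230 nM. All three differ only in the group attached to the carbonyl carbon. Among these three numbers compound 3 has the second highest; its nearest neighbour is compound 1, which sits within the scatter of it, while compound 2 lies further off: a 3.2-fold lower number from compound 2 to compound 3 (0.50 log units; beyond the scatter).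

Compound 4 `CC1CN(C(=O)c2c(N)sc(-c3ccc(Cl)cc3)c2-c2ccc(Cl)cc2)CCN1` has not yet been measured. It differs from compound 3 in one place: 3-methylpiperazin-1-yl in place of 2,4-dioxopiperidin-1-yl on a carbonyl carbon. The steps already measured at the same position show how much this end of the molecule matters. a 1.3-fold higher number from compound 1 to compound 3 (0.10 log units; within the scatter), a 4.0-fold higher number from compound 1 to compound 2 (0.61 log units; beyond the scatter) and a 3.2-fold lower number from compound 2 to compound 3 (0.50 log units; beyond the scatter) together indicate that exchanging the group on the carbonyl carbon moves the number only modestly, and in one case not beyond the scatter. Among the compounds with values here, no measured compound carries the 3-methylpiperazin-1-yl group, so the direction cannot be read from the data. A small change, within the scatter or slightly beyond it, is therefore expected for a 1.1-fold lower number from compound 3 to compound 4 (0.04 log units; within the scatter). Compound 4 is estimated at 8500 nM, with a range from 3000 nM to 25000 nM.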

Compound 4, half-maximal inhibitory concentration: 7210 nM
For compound 4 the middle estimate is 1.2-fold (0.07 log units) above the measured one, and the stated range covers the measured number.
By their numbers in this assay, from the lowest: compounds 4, 1 and 3 (each within the scatter of the next); then compound 2.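

In this assay the change at the carbonyl carbon replaces a ring with 1 hetero atom and 2 double bonds outside aromatic rings by one with 2 hetero atoms and 1 hydrogen-bond donor, yet the number stays within the scatter (a 1.3-fold lower number from compound 3 to compound 4 (0.11 log units; within the scatter)). The step to the cyclohexylamino compound also lies within the scatter (a 1.0-fold lower number from compound 1 to compound 4 (0.01 log units; within the scatter)), so this position accepts three quite different groups, one of them with an amide hydrogen and a non-ring attachment through nitrogen and two of them attached through a ring nitrogen, without a separation among compound 1, compound 3 and compound 4. Only the (4-methoxybenzyl)amino group stands apart, now against all three others, and compound 4 adds one more step beyond the scatter, though still a modest one (a 4.1-fold lower number from compound 2 to compound 4 (0.61 log units; beyond the scatter)).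

As far as these compounds go, whether a plain benzylamino group without the methoxy, a piperazine without the methyl or a group bearing a carboxylic acid would fall with compound 2 or with the other three remains open. Nothing at hand explains why the number hardly moves across these groups or why compound 2 stands apart.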